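Oxime to benzoyl on the sulfur-linked chain of compound 3

This account rests on a few compounds, and the source may have more. Where it says the series, first, only, none or still open, it means among the compounds named here.

Of the compounds shown here, three sharing one core have been tested in a functional assay on the whole organism (strain albino) for inhibition, with Rattus norvegicus as the target, read by paw edema, with a stated time of 1 h, at a dose of 0.28 mmol/kg by the oral route; a lower number here means less inhibition, a higher number more inhibition at the dose given (going by the name of the read-out). Compound 1, `C=CCn1c(SCC(=O)c2ccccc2)nnc1-c1ccc(OC)c(OC)c1`, gives 61%; compound 2, `CCn1c(SCC(=O)c2ccccc2)nnc1-c1cc(OC)c(OC)c(OC)c1`, gives 29%; compound 3, `C=CCn1c(SC/C(=N/O)c2ccccc2)nnc1-c1cc(OC)c(OC)c(OC)c1`, gives 61%. Compound 3 stands level with compound 1 at the digits printed, the two together the highest of the three numbers, while compound 2 lies a good way lower, beyond the scatter. Compound 4, `C=CCn1c(SCC(=O)c2ccccc2)nnc1-c1cc(OC)c(OC)c(OC)c1`, has not yet been measured. It differs from compound 3 in one place: a group of 8 heavy atoms (7 carbon, 1 oxygen; one six-membered aromatic ring of carbon only) in place of a group of 9 heavy atoms (7 carbon, 1 nitrogen, 1 oxygen; one six-membered aromatic ring of carbon only), on a saturated chain carbon bound to a sulfur. Compound 4 shares its benzoyl group with compound 2 yet its other parts with compound 1, so a small drop in this assay is expected, possibly within the scatter; the step of a number 11 percentage points lower from compound 3 to compound 4 (beyond the scatter) is the estimate. Compound 4 is expected to give about 50%, between 30% and 68%.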

Compound 4, a percentage reported as inhibition, in the whole organism at one dose (the size of the read-out at that dose, not a potency): 49%
For compound 4 the middle estimate is 1 percentage points above the measured one, and the stated range covers the measured number.
By their numbers in this assay, from the lowest: compound 2; then compound 4; then compounds 1 and 3 (each within the scatter of the next).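

For the compounds shown here, compound 4 makes each single change readable for the first time: in this assay, benzoyl in place of the oxime-bearing group on the saturated chain carbon bound to a sulfur gives a number 12 percentage points lower from compound 3 to compound 4 (beyond the scatter). Vinyl in place of methyl on a saturated chain carbon bound to an aromatic nitrogen gives a number 20 percentage points higher from compound 2 to compound 4 (beyond the scatter), and methoxy in place of hydrogen on an aromatic carbon gives a number 12 percentage points lower from compound 1 to compound 4 (beyond the scatter). Nothing available explains these steps. Open, from the compounds shown here alone, is whether the oxime-bearing group would give a similar step on the core of compound 1 or compound 2, and how an amine or a carboxylic acid would read at the sulfur-linked chain.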